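The source may report more compounds than this note shows. Statements on the series, on what has been measured and on what is new or still open speak of the compounds shown alone.

Compound 1 `CCc1cc(C(C)=O)c(O)cc1OCCCCCC(C)(C)c1nnn(C)n1` was examined in an assay on isolated protein for inhibition of leukotriene B4 receptor 1 (Homo sapiens), tested at 10 uM (a higher number here means more inhibition at the concentration tested (going by the name of the read-out), a lower number less inhibition), where compound 1 gives 95%. Of the two numbers in hand it is the higher, but its companion compound 2 `C=CCc1cc(C(C)=O)c(O)cc1OCCCCCC(=O)NO`, which in this assay gives 85%, lies within the usual scatter of it, so the two cannot be ranked. Compound 3 `CCc1cc(C(C)=O)c(O)cc1OCCCCCCC(=O)Nc1nn[nH]n1` differs from compound 1 in one place: ((2H-tetrazol-5-yl)carbamoyl)methyl in place of 1-methyl-1-(2-methyl-2H-tetrazol-5-yl)ethyl on a saturated chain carbon, five bonds along the chain from an oxygen on an aromatic ring. Within the data shown here, with no comparable step measured, the change from compound 1 to compound 3 is expected to shift inhibition by a number 10 percentage points lower from compound 1 to compound 3 (within the scatter), not beyond the scatter. Compound 3 is therefore estimated at 85%, between 55% and 98%.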

Compound 3, a percentage reported as inhibition, at one concentration (the size of the read-out at that concentration, not a potency): 101%
Estimate against measurement, compound 3: 16 percentage points below; measured number outside the range, above it.
By their numbers in this assay, from the lowest: compounds 2, 1 and 3 (each within the scatter of the next, the first and the last beyond it).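

At this saturated chain carbon, ((2H-tetrazol-5-yl)carbamoyl)methyl can replace 1-methyl-1-(2-methyl-2H-tetrazol-5-yl)ethyl with no change beyond the scatter in this assay, the step being a number 6 percentage points higher from compound 1 to compound 3 (within the scatter). Inhibition at the concentration tested therefore stays within the scatter even though the entering group has hydrogen-bond donors and a double bond outside aromatic rings, neither of which the leaving group has. Nothing measured here bears on the reason for this result. Going by these compounds, whether a carboxylic acid or an amine on this chain carbon would keep the inhibition stays open. On these data alone, a reading at one concentration gives no potency, so how compound 1 and compound 3 compare in potency also stays open.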